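Methylcarbamoyl in Place of Methylsulfonyl on Compound 1

The source may hold more compounds than are shown below. What is called first, only, known or untested is meant among the compounds shown, and "the series" means these compounds.

Compound 1, `CNc1nc(NCc2ccc(S(C)(=O)=O)cc2)cc(-c2ccccn2)n1`: 185 nM
Compound 2, `COCCNc1nc(NCC2CC2)cc(-c2ccccn2)n1`: 10000 nM
Compound 3, `CNc1nc(NCc2ccc(Cl)cc2Cl)cc(-c2ccccn2)n1`: 0.5 nM

All three compounds share one core and were tested in a functional assay on HEK293 cells for agonist activity at G-protein coupled receptor 39 (Mus musculus), read by inositol phosphate accumulation; on this read-out higher numbers stand for an effect only at larger amounts of compound and lower numbers for an effect already at smaller amounts. Among the three numbers, compound 1 holds the second highest. Compound 2 lies above it, and the gap between them is beyond the scatter. Compound 3 lies far below compound 1, again beyond the scatter, and it also lies far below compound 2.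

The untested compound 4, `CNC(=O)c1ccc(CNc2cc(-c3ccccn3)nc(NC)n2)cc1`, is built from compound 1 by one change at the benzyl arm: methylcarbamoyl in place of methylsulfonyl on an aromatic carbon. Among the measured compounds shown here, nothing among the measured compounds isolates this exchange, so no measured step can be read off for it. Both groups sit on the same aromatic carbon, para to a large group, and both bring four heavy atoms without a ring. For the measured compounds named here, with no step of this kind to lean on, the change is expected to shift the read-out little, if at all, and any shift is more likely toward a higher number than a lower one.

Compound 4 is therefore estimated at 300 nM, with a range from 60 nM to 1500 nM. That estimate corresponds to a step of a 1.6-fold higher number from compound 1 to compound 4 (0.21 log units; within the scatter) expected to stay close to the scatter.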

Compound 4, half-maximal effective concentration: 8 nM
Compound 4: the middle estimate sits 38-fold (1.57 log units) above what was measured; measured number below the stated range.
By their numbers in this assay, from the lowest: compound 3; then compound 4; then compound 1; then compound 2.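

In this assay, putting methylcarbamoyl in place of methylsulfonyl on an aromatic carbon, para to a large group, gives a 23-fold lower number from compound 1 to compound 4 (1.36 log units; beyond the scatter), so this place on the benzyl arm responds strongly to which of the two groups it carries. The earlier compounds shown here differ from one another in more than one place, so they could not tie any gap to a single group, whereas this pair does, and it does so with two groups of equal heavy-atom count, neither with a ring. The two groups differ in their counts of hydrogen-bond donors, hydrogen-bond acceptors and double bonds, but nothing available says which of these differences, if any, accounts for the step.

The compounds shown leave open how an unsubstituted carboxamide, a dimethylcarbamoyl group or a carboxylic acid would read on the same aromatic carbon, and so which part of methylcarbamoyl the step depends on. They also leave open whether methylcarbamoyl would bring a step of similar size on the benzyl arm of compound 3, or with the methylamino group of the shared core replaced by a longer chain.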